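This account rests on a few compounds, and the source may have more. Where it says the series, first, only, none or still open, it means among the compounds named here.

Compound 1 `CCCCCCCCCCc1ccc(-c2noc([C@@H]3CCCN3)n2)cc1` carries a pyrrolidin-2-yl group on the shared core. In an assay on HeLa cells for inhibition of sphingosine-1-phosphate transporter SPNS2 (Mus musculus), read by LC-MS, tested at 2 uM (a lower number here means less inhibition, a higher number more inhibition at the concentration tested (going by the name of the read-out)), compound 1 gives 21%, the lowest of the two numbers recorded so far. Compound 2 `CCCCCCCCCCc1ccc(-c2noc(C3CCNCC3)n2)cc1` differs from it in one place, with piperidin-4-yl in place of pyrrolidin-2-yl on an aromatic carbon, and in this assay compound 2 gives 66%; the step of a number 45 percentage points higher from compound 1 to compound 2 (beyond the scatter) shows that a change at this one position can move the read-out a long way. Compound 3 `CCCCCCCCCCc1ccc(-c2noc(CC(O)CN3CCCC3)n2)cc1` has not been measured in this assay. Compared with compound 1 it changes at the same position: 2-hydroxy-3-(pyrrolidin-1-yl)propyl in place of pyrrolidin-2-yl on an aromatic carbon. Among the measured compounds shown here, only the step from compound 1 to compound 2 bears on it, and it was large and upward, so a similar upward step, a number 29 percentage points higher from compound 1 to compound 3 (beyond the scatter), is expected here. For compound 3 in this assay the estimate is 50%, with a range from 20% to 80%.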

Compound 3, a percentage reported as inhibition, at one concentration (the size of the read-out at that concentration, not a potency): 21%
Compound 3: middle estimate off by 29 percentage points, on the high side, and the stated range covers the measured number.
By their numbers in this assay, from the lowest: compounds 1 and 3 (each within the scatter of the next); then compound 2.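

The larger 2-hydroxy-3-(pyrrolidin-1-yl)propyl group gives no change at the digits printed from compound 1 to compound 3 (within the scatter) in this assay, so adding atoms at this position does not by itself raise the read-out. The change also gives a number 45 percentage points lower from compound 2 to compound 3 (beyond the scatter) and leaves compound 3 well short of compound 2, which shows that the earlier rise goes with piperidin-4-yl and does not extend to every replacement of pyrrolidin-2-yl. No measurement available here accounts for these differences.

From the compounds shown here alone, it remains open whether the rise depends on the six-membered ring or on where its nitrogen sits, which piperidin-3-yl at the same position would test. Going by these compounds, the role of the hydroxyl is also open, and 3-(pyrrolidin-1-yl)propyl, the same chain without it, would address that question.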